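Bromopyridinyl cyanoacrylamides: halogen swap on the aryl ring

The source may report more compounds than this note shows. Statements on the series, on what has been measured and on what is new or still open speak of the compounds shown alone.

Measured so far:
- compound 1, `C[C@H](NC(=O)/C(C#N)=C/c1cccc(Br)n1)c1ccc(Br)cc1`, in a functional assay on U-266 cells (Homo sapiens) for antiproliferative activity, read by MTT assay, with a stated time of 72 h (on this read-out lower numbers stand for stronger inhibition and higher numbers for weaker inhibition), gives 1800 nM
- compound 2, `N#C/C(=C\c1cccc(Br)n1)C(=O)N[C@@H]1CCCc2ccccc21`, in this assay gives 1900 nM
- compound 3, `C[C@H](NC(=O)/C(C#N)=C/c1cccc(Br)n1)c1cccc(C(F)(F)F)c1`, in this assay gives 1600 nM

The three measured compounds share the same cyanoacrylamide core and differ only in the amine-derived part. Compound 1 stands second highest of the three numbers, but its gaps to compound 2 and to compound 3 are both within the scatter of repeated measurement, so no order among them can be read from these values.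

Compound 4, `C[C@H](NC(=O)/C(C#N)=C/c1cccc(Br)n1)c1ccc(F)cc1`, is the next member and has not been measured in this assay. It differs from compound 1 as follows: fluoro in place of bromo on an aromatic carbon. For the measured compounds named here, nothing in the measured set tells what this kind of swap does here, since no pair of measured compounds differs in a single place; the only guidance is that variation of the amine-derived part among compounds 1, 2 and 3 left the numbers within the scatter.

The step of a 1.2-fold higher number from compound 1 to compound 4 (0.09 log units; within the scatter) is expected to be small and possibly toward a higher number. Compound 4 is estimated at 2200 nM, with a range from 1200 nM to 4500 nM.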

Compound 4, half-maximal inhibitory concentration: 1400 nM
Compound 4: the middle estimate sits 1.6-fold (0.20 log units) above what was measured; measured number inside the range.
By their numbers in this assay, from the lowest: compounds 4, 3, 1 and 2 (each within the scatter of the next).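

For the compounds shown here, the swap from 4-bromophenyl to 4-fluorophenyl gives the first comparison that differs in one place only. In this assay, the step is a 1.3-fold lower number from compound 1 to compound 4 (0.11 log units; within the scatter), so at this aromatic carbon, para to a large group, bromo and fluoro cannot be told apart by their numbers. No measurement at hand links this outcome to any property of either halogen.

The compounds shown leave open whether this position responds at all to a group other than a halogen, such as an amine, a carboxylic acid or a methoxy group. Also open, on these data alone, is whether fluoro in place of the bromo on the shared core would give a similarly small step.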